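The compounds below may be only part of what the source reports. "The series", "measured", "known", "first", "only" and "open" are said of these compounds alone.

Three compounds with a shared core have been examined in an ADME assay on microsomes from liver (Homo sapiens) for metabolic stability, read by LC-MS, using NADPH; a higher number here means that the compound lasts longer, a lower number that the compound disappears faster. Compound 1, `Fc1ccccc1Nc1nc(-c2ccccn2)cs1`, gives 0.103 h. Compound 2, `COc1ccccc1Nc1nc(-c2ccccn2)cs1`, gives 0.145 h. Compound 3, `COc1cccc(-c2csc(Nc3ccccc3F)n2)c1`, gives 0.137 h; its number and those of compound 1 and compound 2 all lie within the usual scatter of one another, so no order among the three can be read from them.

Compound 2 and compound 1 differ in one place, (fluoro in place of methoxy on an aromatic carbon), and that change brought a 1.4-fold lower number from compound 2 to compound 1 (0.15 log units; within the scatter).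

Compound 4, `Fc1cccc(-c2csc(Nc3ccccc3F)n2)c1`, has not yet been measured in this assay. It differs from compound 3 in one place, (fluoro in place of methoxy on an aromatic carbon). The difference between the core of compound 3 and that of compound 2 is not broken down here. The change from compound 3 to compound 4 is the same kind of change as that from compound 2 to compound 1, but not the same: in compound 1 the fluoro stands ortho to a large group, whereas in compound 4 it stands meta to a large group.

Among the measured compounds shown here, for compound 4 the expected step is a 1.2-fold lower number from compound 3 to compound 4 (0.10 log units; within the scatter), a small one, because the one earlier instance of this change, a 1.4-fold lower number from compound 2 to compound 1 (0.15 log units; within the scatter), stayed within the scatter. On that basis the value of compound 4 in this assay is estimated at 0.11 h, most likely between 0.06 h and 0.2 h.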

Compound 4, half-life in the Homo sapiens assay: 0.38 h
Estimate against measurement, compound 4: 3.5-fold (0.54 log units) below; measured number above the stated range.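

In the Homo sapiens assay compound 3 gives 0.137 h and compound 4 gives 0.38 h, and the replacement of methoxy by fluoro gave a 2.8-fold higher number from compound 3 to compound 4 (0.44 log units; beyond the scatter). The same change did not give the same result on the two cores: the same change on two cores in the Homo sapiens assay, a 1.4-fold lower number (0.15 log units; within the scatter) from compound 2 to compound 1 and a 2.8-fold higher number (0.44 log units; beyond the scatter) from compound 3 to compound 4, 3.9-fold (0.59 log units) apart, beyond the scatter of two such steps. This shows that the step on the core of compound 2 was no reliable guide to the step on the core of compound 3, but it does not show what lies behind the gap, and with one pair on each core, and the fluoro standing in a different place in each pair, the effect of the core cannot be told apart from that of the place. In a physicochemical assay for solubility, using the shake flask method, measured as kinetic solubility, at pH 7.4 (a higher number here means a more soluble compound, a lower number a less soluble compound), compound 3 gives 49300 nM. In the physicochemical assay compound 4 gives < 1000 nM, which is a limit of the assay and not a number. Going by these compounds, in the physicochemical assay the same change brought an at least 49-fold lower number from compound 3 to compound 4 (1.69 log units; beyond the scatter), a step that rests on a limit of the assay for compound 4, so its true size remains unknown.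

On these data alone, it remains open whether the higher number in the Homo sapiens assay can be kept without the lower number in the physicochemical assay, and whether the step seen for compound 3 and compound 4 would hold on any further core. The compounds shown carry only methoxy or fluoro at this place on the core of compound 3, so it is also open how a group such as a nitrile, an amine or a carboxylic acid would read in these two assays.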